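This account rests on a few compounds, and the source may have more. Where it says the series, first, only, none or still open, it means among the compounds named here.

Measured compounds in a functional assay on HL-60 cells (Homo sapiens) for inhibition, read by CCK-8 assay, with a stated time of 48 h; a higher number here means a weaker inhibitor, a lower number a stronger inhibitor:
- compound 1 `O=C(NCCNS(=O)(=O)c1ccc(-c2ccccc2O[C@H]2CC[C@@H](O)CC2)s1)Nc1ccc([N+](=O)[O-])cc1` gives > 20000 nM, a limit of this assay.
- compound 2 `O=[N+]([O-])c1ccc(NC(=S)NCCNS(=O)(=O)c2ccc(-c3ccccc3O[C@H]3CC[C@@H](O)CC3)s2)cc1` gives > 50000 nM, also a limit of this assay.
- compound 3 `Cc1ccc(-c2ccsc2S(=O)(=O)NCCNC(=O)Nc2ccc([N+](=O)[O-])cc2)c(Oc2ccc(O)c(O)c2)c1` gives 3900 nM.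

Compound 1 and compound 2 differ by a group of 12 heavy atoms (7 carbon, 2 nitrogen, 2 oxygen, 1 sulfur; one six-membered aromatic ring of carbon only) in place of a group of 12 heavy atoms (7 carbon, 2 nitrogen, 3 oxygen; one six-membered aromatic ring of carbon only), on an amine nitrogen. The step that the two limits leave unreadable from compound 1 to compound 2 cannot be sized, since compound 1 sits at the limit of > 20000 nM in this assay, at which 1 of the 3 values shown sits, and compound 2 sits at the limit of > 50000 nM in this assay, at which 1 of the 3 values shown sits. The difference between the core of compound 1 and the core of compound 3 is not broken down here.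

Compound 4 `Cc1ccc(-c2ccsc2S(=O)(=O)NCCNC(=S)Nc2ccc([N+](=O)[O-])cc2)c(Oc2ccc(O)c(O)c2)c1` is compound 3 with a group of 12 heavy atoms (7 carbon, 2 nitrogen, 2 oxygen, 1 sulfur; one six-membered aromatic ring of carbon only) in place of a group of 12 heavy atoms (7 carbon, 2 nitrogen, 3 oxygen; one six-membered aromatic ring of carbon only), on an amine nitrogen, the same change as from compound 1 to compound 2, at the same place. For compound 4 a step of a 1.0-fold higher number from compound 3 to compound 4 (0.01 log units; within the scatter) is expected in this assay. This expectation rests on compound 3 giving 3900 nM and on the step from compound 1 to compound 2 being unreadable, so no direction is indicated. Compound 4 is therefore estimated at 4000 nM, with a range from 1500 nM to 12000 nM.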

Compound 4, half-maximal inhibitory concentration: 2900 nM
Compound 4: middle estimate off by 1.4-fold (0.14 log units), on the high side, and the stated range covers the measured number.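

On the core of compound 3, sulfur in place of the carbonyl oxygen of the (4-nitrophenyl)carbamoyl group gives a 1.3-fold lower number from compound 3 to compound 4 (0.13 log units; within the scatter) in this assay, so the two compounds cannot be told apart. Compound 1 gives > 20000 nM, a limit of the assay. Compound 2 gives > 50000 nM, also a limit, so the step on that core cannot be read, and whether the change behaves alike on both cores is not shown.

The compounds shown leave open whether the result on the core of compound 3 would hold on a further core. They also leave open how an amine or a carboxylic acid in place of the nitro group would read in this assay.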